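This account rests on a few compounds, and the source may have more. Where it says the series, first, only, none or still open, it means among the compounds named here.

In a functional assay on KBVIN cells (Homo sapiens) for cytotoxicity, read by MTT assay, with a stated time of 72 h (on this read-out lower numbers stand for an effect already at smaller amounts and higher numbers for an effect only at larger amounts of compound), compound 3, `CCc1cccc2c(OC)c(-c3occ(C)c3CO)ccc12`, gives 6.6 ug/mL. Compound 2, `CCOc1c(-c2occ(C)c2C(=O)OC)ccc2c(CC)cccc12`, gives 1.7 ug/mL in this assay, so compound 3 stands at the higher of the two numbers measured. Compound 1, `CCOc1c(-c2occ(C)c2C(=O)O)ccc2c(CC)cccc12`, reaches only the limit of > 10 ug/mL in this assay. Within the data shown here, the single measured step, an at least 5.8-fold lower number from compound 1 to compound 2 (0.76 log units; beyond the scatter), concerns a different part of the molecule. Compound 4, `CCOc1c(-c2occ(C)c2CO)ccc2c(CC)cccc12`, differs from compound 3 by methyl in place of hydrogen on a saturated chain carbon bound to an oxygen on an aromatic ring. Among the measured compounds shown here, no measured step bears on this change; compounds 1 and 2 both carry the ethoxy group and differ from each other elsewhere. A step not beyond the scatter is therefore expected, a 1.2-fold lower number from compound 3 to compound 4 (0.08 log units; within the scatter). Compound 4 is thus estimated to give about 5.5 ug/mL in this assay, within a range from 2 ug/mL to 12 ug/mL.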

Compound 4, concentration for half-maximal effect: 6.4 ug/mL
Compound 4: the middle estimate sits 1.2-fold (0.07 log units) below what was measured; measured number inside the range.
By their numbers in this assay, from the lowest: compound 2; then compounds 4 and 3 (each within the scatter of the next). At a limit, above all of these: compound 1.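

Methoxy to ethoxy gives a 1.0-fold lower number from compound 3 to compound 4 (0.01 log units; within the scatter) in this assay, the first direct test of this change, and so makes no difference that can be read. With the ethoxy group kept, hydroxymethyl in place of methoxycarbonyl on an aromatic carbon does count, giving a 3.8-fold higher number from compound 2 to compound 4 (0.58 log units; beyond the scatter). Compound 1 stands only at a limit. Hydroxymethyl in place of carboxy on an aromatic carbon gives an at least 1.5-fold lower number from compound 1 to compound 4 (0.19 log units; that floor lies within the scatter), a step that cannot be read further: the limit of > 10 ug/mL in this assay, at which 1 of the 4 values shown sits.

From the compounds shown here alone, whether this oxygen also tolerates a longer chain, such as propoxy or benzyloxy, stays open. So does whether an amine at the aromatic carbon would bring a lower number than hydroxymethyl.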